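A few compounds are considered here, and "the series" means these few. Any claim that something is new, unique, unknown or untested is made for them only; others in the source may bear on it.

Measured so far in a functional assay on HL-60 cells (Homo sapiens) for inhibition, read by CCK-8 assay, with a stated time of 48 h; a lower number here means a stronger inhibitor, a higher number a weaker inhibitor:
compound 1 `O=C(NCCNS(=O)(=O)c1ccc(-c2ccccc2Oc2ccc([N+](=O)[O-])c([N+](=O)[O-])c2)s1)Nc1ccc([N+](=O)[O-])cc1` gives 340 nM
compound 2 `O=S(=O)(c1sccc1-c1ccccc1Oc1ccc(O)c(O)c1)N1CCN(C(=S)Nc2ccc(Cl)cc2)CC1` gives 5500 nM
compound 3 `O=C(NCCNS(=O)(=O)c1ccc(-c2ccccc2Oc2ccc([N+](=O)[O-])c([N+](=O)[O-])c2)s1)Nc1ccc(Cl)cc1` gives 8100 nM

Compound 3 and compound 1 share a core and differ in one place: nitro in place of chloro on an aromatic carbon. That single change gives a 24-fold lower number from compound 3 to compound 1 (1.38 log units; beyond the scatter), a large step in this assay. Compound 2 stands nearest to compound 3; the two values lie within the scatter of each other, so no order between compound 2 and compound 3 is read from them. Against compound 1, compound 2 sits well beyond the scatter. The difference between the core of compound 2 and the core of compound 3 is not broken down here.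

Compound 4 `O=[N+]([O-])c1ccc(NC(=S)N2CCN(S(=O)(=O)c3sccc3-c3ccccc3Oc3ccc(O)c(O)c3)CC2)cc1` is not yet measured. It relates to compound 2 as compound 1 relates to compound 3: nitro in place of chloro on an aromatic carbon. The place of the change reads the same in both pairs, but the cores carrying it differ, so this is the same change set on another core. The expectation for compound 4 in this assay is a step of a 9.2-fold lower number from compound 2 to compound 4 (0.96 log units; beyond the scatter), kept smaller than the measured one because a 24-fold lower number from compound 3 to compound 1 (1.38 log units; beyond the scatter) rests on one pair alone and nothing shows that the core of compound 2 answers alike. Compound 4 is thus expected near 600 nM, with the likely range from 150 nM to 3000 nM.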

Compound 4, half-maximal inhibitory concentration: 5300 nM
Compound 4: middle estimate off by 8.8-fold (0.95 log units), on the low side; measured number above the stated range.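

In this assay, nitro in place of chloro on an aromatic carbon does not carry over unchanged from one core to the other: the same change on two cores in this assay, a 24-fold lower number (1.38 log units; beyond the scatter) from compound 3 to compound 1 and a 1.0-fold lower number (0.02 log units; within the scatter) from compound 2 to compound 4, 23-fold (1.36 log units) apart, beyond the scatter of two such steps. On the core of compound 2 the change gives a 1.0-fold lower number from compound 2 to compound 4 (0.02 log units; within the scatter), so no order is read between these two compounds, while on the core of compound 3 the same change gives a 24-fold lower number from compound 3 to compound 1 (1.38 log units; beyond the scatter). This shows that in these two pairs the outcome of the change differs with the core, but it does not show which part of the cores matters, and each step rests on one pair alone.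

The compounds shown leave open whether the large step on the core of compound 3 is specific to nitro or also appears with another group on the same aromatic carbon, such as an amine, a carboxylic acid or a nitrile. Also open, on these data alone, is whether any other group at that place moves the number on the core of compound 2.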